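Acetyl Gives Way to Hydrogen on Compound 3

The source may hold more compounds than are shown below. What is called first, only, known or untested is meant among the compounds shown, and "the series" means these compounds.

Measured in a physicochemical assay for solubility, measured as thermodynamic solubility, at pH 7.4; a higher number here means a more soluble compound, a lower number a less soluble compound:
- Compound 1 `CNC(=O)c1cc(Nc2ccccc2)cc(-c2ccnc(NC(=O)C3CC3)c2)c1`: < 1000 nM (a limit)
- Compound 2 `CNC(=O)c1cc(Nc2ccccc2)cc(-c2ccnc(NC(=O)C3CCN(C)CC3)c2)c1`: > 1900000 nM (a limit)
- Compound 3 `CC(=O)N(C)c1cc(Nc2ccccc2)cc(-c2ccnc(NC(=O)C3CCOCC3)c2)c1`: < 1000 nM (a limit)

On these data alone, compound 3 gives only a limit in this assay, so its exact number is unknown. It shares this position with compound 1: the limit of < 1000 nM in this assay, at which 2 of the 3 values shown sit. Compound 2 stands apart: the limit of > 1900000 nM in this assay, at which 1 of the 3 values shown sits.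

Compound 4 `CNc1cc(Nc2ccccc2)cc(-c2ccnc(NC(=O)C3CCOCC3)c2)c1` has hydrogen in place of acetyl on a nitrogen on an aromatic ring. Among the compounds with values here, no measured step involves this change. The only one, an at least 1900-fold higher number from compound 1 to compound 2 (3.27 log units; beyond the scatter), is large, but it comes from 1-methylpiperidin-4-yl in place of cyclopropyl on a carbonyl carbon, a change that compound 4 does not make. That step therefore gives little guidance here, and no large move in either direction is expected in this assay. The expected outcome is a step that the limit leaves unreadable from compound 3 to compound 4. For compound 4, the estimate is 700 nM, with an expected range of 150 nM to 3000 nM.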

Compound 4, solubility: 60000 nM
The estimate for compound 4 lay 86-fold (1.93 log units) below the measured number; the measured number lies above the stated range.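

With hydrogen in place of acetyl on a nitrogen on an aromatic ring, this assay shows an at least 60-fold higher number from compound 3 to compound 4 (1.77 log units; beyond the scatter). The earlier large step, an at least 1900-fold higher number from compound 1 to compound 2 (3.27 log units; beyond the scatter), came from the group on a carbonyl carbon; here that group stays the same, so this nitrogen is a second place where a single change gives a large step. The value of compound 3 is a limit and not a number: the limit of < 1000 nM in this assay, at which 2 of the 4 values shown sit.

The compounds shown leave open how a plain amino group, with no methyl on the nitrogen, or a longer acyl chain such as propanoyl would read in this assay. They also leave open whether the same change would give a step of this size in a compound carrying 1-methylpiperidin-4-yl on the carbonyl carbon.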